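Methyl on the second aryl ring: compound 3 to compound 4

The source may report more compounds than this note shows. Statements on the series, on what has been measured and on what is new or still open speak of the compounds shown alone.

Compound 1 `CC1=C(C(=O)SC(C)(C)C)C(c2ccccc2)C=C(c2ccccc2)N1` in an assay on SH-SY5Y cells for inhibition of Voltage-dependent L-type calcium channel subunit alpha-1D (Homo sapiens), read by calcium flux, with a stated time of 15 min (a higher number here means a weaker inhibitor, a lower number a stronger inhibitor), gives 95800 nM.
Compound 2 `CC1=C(C(=O)SC(C)(C)C)C(c2ccc(Br)cc2)C=C(c2ccc(C)cc2)N1` in this assay gives 59600 nM.
Compound 3 `CC1=C(C(=O)SC(C)(C)C)C(c2ccc(C)cc2)C=C(c2ccccc2)N1` in this assay gives 56200 nM.

All three numbers fall within the scatter of one another. Compound 3 sits nearest to compound 2, and its gap from compound 1 is a 1.7-fold lower number from compound 1 to compound 3 (0.23 log units; within the scatter). Compound 4 `CC1=C(C(=O)SC(C)(C)C)C(c2ccc(C)cc2)C=C(c2ccc(C)cc2)N1` differs from compound 3 by methyl in place of hydrogen on an aromatic carbon; read one bond further out, the change is phenyl to 4-methylphenyl, the new group para to a large group. Among the measured compounds shown here, the only measured step of the same kind, a 1.7-fold lower number from compound 1 to compound 3 (0.23 log units; within the scatter), stayed within the scatter, and compound 2, which also carries a methyl on an aromatic carbon, does not separate from compound 3 either. No change beyond the scatter is therefore expected in this assay, a 1.1-fold lower number from compound 3 to compound 4 (0.05 log units; within the scatter). Compound 4 is estimated at 50000 nM, with a range from 20000 nM to 125000 nM.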

Compound 4, half-maximal inhibitory concentration: > 100000 nM
Compound 4: a limit, no number (the forecaster's own chance of this, stated with the estimate: 10%); at least 2.0-fold (0.30 log units) between middle value and limit.
By their numbers in this assay, from the lowest: compounds 3, 2 and 1 (each within the scatter of the next). At a limit, above all of these: compound 4.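

Compound 4 carries a limit and not a number in this assay, the only such reading among the compounds shown: the limit of > 100000 nM in this assay, at which 1 of the 4 values shown sits. Phenyl to 4-methylphenyl at this place gives an at least 1.7-fold higher number from compound 3 to compound 4 (0.25 log units; that floor lies within the scatter), and methyl in place of bromo gives an at least 1.6-fold higher number from compound 2 to compound 4 (0.22 log units; that floor lies within the scatter). Both floors lie within the scatter, so the methyl para to a large group gives no sign of a lower number, and the size of any rise stays unfixed.

From the compounds shown here alone, how an amine, a carboxylic acid or a longer chain would read in place of this methyl remains open. Going by these compounds, the real value of compound 4 also remains open.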